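This account rests on a few compounds, and the source may have more. Where it says the series, first, only, none or still open, it means among the compounds named here.

Working notes on the series, continued.

The three measured compounds share a core and differ only in the chain on the saturated carbon carrying the aromatic ring. Compound 1 `CCC[C@H](c1ccc(C(=O)NCc2nn[nH]n2)cc1)N1C(=O)C(c2cc(Cl)cc(Cl)c2)=N[C@]12CC[C@@H](C(C)(C)C)CC2` gives 55 nM in an assay on CHO cells for displacement of a labelled ligand from Glucagon receptor (Homo sapiens), read by scintillation counting, with a stated time of 60 min; a lower number here means a stronger inhibitor, a higher number a weaker inhibitor. Compound 2 `CCCCC[C@H](c1ccc(C(=O)NCc2nn[nH]n2)cc1)N1C(=O)C(c2cc(Cl)cc(Cl)c2)=N[C@]12CC[C@@H](C(C)(C)C)CC2` gives 24 nM in this assay. Compound 3 `CC(C)CC[C@H](c1ccc(C(=O)NCc2nn[nH]n2)cc1)N1C(=O)C(c2cc(Cl)cc(Cl)c2)=N[C@]12CC[C@@H](C(C)(C)C)CC2` gives 22 nM in this assay. The steps run a 2.3-fold lower number from compound 1 to compound 2 (0.36 log units; beyond the scatter) and a 2.5-fold lower number from compound 1 to compound 3 (0.40 log units; beyond the scatter), while a 1.1-fold lower number from compound 2 to compound 3 (0.04 log units; within the scatter). Compound 3 thus holds the lowest number shown, but its gap to compound 2 is within the scatter, so no order between those two is claimed.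

Compound 4 `CC1(CC[C@H](c2ccc(C(=O)NCc3nn[nH]n3)cc2)N2C(=O)C(c3cc(Cl)cc(Cl)c3)=N[C@]23CC[C@@H](C(C)(C)C)CC3)CC1` differs from compound 3 by 1-methylcyclopropyl in place of isopropyl on a saturated chain carbon, three bonds along the chain from an amide-type nitrogen in a ring and an aromatic carbon. Among the compounds with values here, the one step at this position that lies beyond the scatter is the modest one from compound 1 to compound 3; the step from compound 2 to compound 3 at the same place stays within the scatter. Both point to a chain of similar size giving a number close to that of compound 3, with no clear direction. Compound 4 is therefore expected at 20 nM in this assay, within 8 nM to 50 nM. That estimated step, a 1.1-fold lower number from compound 3 to compound 4 (0.04 log units; within the scatter), is expected to stay within the scatter.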

Compound 4, half-maximal inhibitory concentration: 17 nM
Compound 4: middle estimate off by 1.2-fold (0.07 log units), on the high side; the range from low to high includes it.
By their numbers in this assay, from the lowest: compounds 4, 3 and 2 (each within the scatter of the next); then compound 1.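

Replacing isopropyl with 1-methylcyclopropyl shows that a three-membered carbon ring can stand on this saturated chain carbon without a readable change in this assay, with a 1.3-fold lower number from compound 3 to compound 4 (0.11 log units; within the scatter) and a 1.4-fold lower number from compound 2 to compound 4 (0.15 log units; within the scatter) as the steps. The step of a 3.2-fold lower number from compound 1 to compound 4 (0.51 log units; beyond the scatter) remains modest, so compound 1 stays apart while compounds 2, 3 and 4 sit together, and the ring adds no separation among those three. No supporting data bear on why these chains read alike.

On these data alone, whether an amine, a carboxylic acid or a longer chain at this place would keep the number near that of compound 4 remains open. So does the reading of a larger carbon ring, such as cyclohexyl, at the same place.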